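The source may hold more compounds than are shown below. What is called first, only, known or untested is meant among the compounds shown, and "the series" means these compounds.

Measured compounds:
- compound 1 `COc1ccc(/C=C/C(=O)c2c(C)cc(O)c(C(=O)/C=C/c3ccc(OC)cc3)c2-c2ccccc2)cc1`: in a functional assay on MDA-MB-231 cells (Homo sapiens) for cytotoxicity, read by MTT assay, with a stated time of 24 h (on this read-out lower numbers stand for stronger inhibition and higher numbers for weaker inhibition), compound 1 is recorded as "not active" (no number reported)
- compound 2 `Cc1cc(O)c(C(=O)/C=C/c2ccc(Cl)cc2)c(-c2ccc(Br)cc2)c1C(=O)/C=C/c1ccc(Cl)cc1`: in this assay compound 2 gives 15000 nM

Compound 1 stands without a number: the read-out for it is given only as "not active" (no number reported), so there is no value to anchor a step from it. For the measured compounds named here, compound 2 does carry a number, but it differs from compound 1 in several places, and no step between the two is computed; the two entries show only that one member of the series reaches a measurable, weak value while compound 1 does not.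

Compound 3 `COc1ccc(/C=C/C(=O)c2c(C)cc(O)c(C(=O)/C=C/c3ccc(OC)cc3)c2-c2ccc(OCc3ccccc3)cc2)cc1` differs from compound 1 in one place: benzyloxy in place of hydrogen on an aromatic carbon. Going by the values given here, no measured step covers this change, so its size in this assay cannot be read from the series. With compound 1 giving "not active" (no number reported), the expectation is that compound 3 stays weak, with at most a modest gain, and a fair chance that compound 3 too is returned without a number. Compound 3 is estimated at 25000 nM, within a range from 6000 nM to 100000 nM.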

Compound 3, half-maximal inhibitory concentration: 12000 nM
The estimate for compound 3 lay 2.1-fold (0.32 log units) above the measured number; low and high end bracket the measured number.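

No step can be read from compound 1 to compound 3: compound 1 is recorded as "not active" (no number reported), while compound 3 gives 12000 nM. No supporting evidence bears on this result. The compounds shown leave open how large a change benzyloxy in place of hydrogen brings to the read-out when both partners carry a number.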